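The source may hold more compounds than are shown below. What is called first, only, known or untested is meant among the compounds shown, and "the series" means these compounds.

In a functional assay (aorta) with Oryctolagus cuniculus as the target (on this read-out lower numbers stand for stronger inhibition and higher numbers for weaker inhibition), compound 1 (`CC1=C(C(CCCCCC(=O)O)c2ccccc2)C(=O)c2ccccc2C1=O`) gives 240 nM and compound 2 (`CC1=C(C)C(=O)C(C(CCCCCC(=O)O)c2ccc(C)cc2)=C(C)C1=O`) gives 1000 nM, the higher of the two numbers, with the gap lying beyond the scatter. Compound 3 (`CC1=C(C)C(=O)C(C(CCCCCC(=O)O)c2ccccc2C)=C(C)C1=O`) has not yet been measured. It carries 2-methylphenyl in place of 4-methylphenyl on a saturated chain carbon bound to a double-bonded ring carbon and a saturated chain carbon. Among the compounds with values here, no measured pair shows this kind of change, so no step beyond the scatter is expected in this assay. The expected step is a 1.1-fold lower number from compound 2 to compound 3 (0.05 log units; within the scatter). For compound 3 the estimated value is 900 nM, within an expected range of 300 nM to 3000 nM.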

Compound 3, half-maximal inhibitory concentration: 3200 nM
Estimate against measurement, compound 3: 3.6-fold (0.55 log units) below; the measured number lies above the stated range.
By their numbers in this assay, from the lowest: compound 1; then compound 2; then compound 3.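

In this assay, the two methylphenyl groups are not interchangeable on a saturated chain carbon bound to a double-bonded ring carbon and a saturated chain carbon: 2-methylphenyl in place of 4-methylphenyl gives a 3.2-fold higher number from compound 2 to compound 3 (0.51 log units; beyond the scatter). Both groups have the same heavy atoms and the same counts, so composition alone does not set the number at this place. Nothing measured here accounts for the step. This single pair leaves open how a chlorophenyl or a methoxyphenyl group would read at this place, and whether the step would recur on the core of compound 1.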